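Pyridine substituent variation in a fused bicyclic amine series

The source may report more compounds than this note shows. Statements on the series, on what has been measured and on what is new or still open speak of the compounds shown alone.

Measured so far:
compound 1 `Brc1cncc(N2C[C@H]3CNC[C@H]3C2)c1` 0.06 nM
compound 2 `CCCOc1cncc(N2C[C@H]3CNC[C@H]3C2)c1` 0.041 nM

In an assay on membranes from brain for displacement of a labelled ligand from Neuronal acetylcholine receptor; alpha4/beta2 (Rattus norvegicus) (on this read-out higher numbers stand for weaker inhibition and lower numbers for stronger inhibition), compound 2 shows the lowest of the two numbers; its nearest neighbour is compound 1, and the two lie within the scatter. Compound 3 `c1ccc(-c2cncc(N3C[C@H]4CNC[C@H]4C3)c2)cc1` carries phenyl in place of propoxy on an aromatic carbon. Among the measured compounds shown here, the only measured step, a 1.5-fold lower number from compound 1 to compound 2 (0.17 log units; within the scatter), bears on it only loosely, since neither that exchange nor any other step touches an aromatic substituent; it was small. A small step in this assay is therefore expected, with no firm direction. Compound 3 is estimated at 0.1 nM (range 0.03 nM to 0.4 nM), a step of a 2.4-fold higher number from compound 2 to compound 3 (0.39 log units; beyond the scatter).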

Compound 3, inhibition constant: 0.16 nM
Compound 3: middle estimate off by 1.6-fold (0.20 log units), on the low side; the measured number falls inside the stated range.
By their numbers in this assay, from the lowest: compounds 2 and 1 (each within the scatter of the next); then compound 3.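

In this assay, the position two atoms from the ring nitrogen now gives its first steps beyond the scatter: phenyl gives a 3.9-fold higher number from compound 2 to compound 3 (0.59 log units; beyond the scatter) and, against bromo, a 2.7-fold higher number from compound 1 to compound 3 (0.43 log units; beyond the scatter). The position therefore accepts a six-membered aromatic ring of carbon only with a modest change, whereas the exchange of bromo for propoxy stayed within the scatter. No evidence here accounts for these steps.

Still open, from the compounds shown here alone, is how an amine or a carboxylic acid would read at this position. Also open, going by these compounds, is whether a longer alkoxy chain or a pyridyl ring would follow propoxy or phenyl.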